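Triazole substituent swap on a bromoquinoline scaffold

The source may report more compounds than this note shows. Statements on the series, on what has been measured and on what is new or still open speak of the compounds shown alone.

Three compounds sharing one core were tested in an ADME assay on PANC-1 cells (Homo sapiens) for cytotoxicity, read by sulforhodamine B assay, with a stated time of 48 h, tested at 10 uM; on this read-out higher numbers stand for more inhibition at the one concentration tested (going by the name of the read-out) and lower numbers for less inhibition. Compound 1 `CCCCCCCc1cn(C(c2ccccc2)c2cc3cc(Br)ccc3nc2OC)nn1` gives 16.6%, compound 2 `CCCCCCc1cn(C(c2ccccc2)c2cc3cc(Br)ccc3nc2OC)nn1` gives 6.08%, and compound 3 `CCOC(=O)c1cn(C(c2ccccc2)c2cc3cc(Br)ccc3nc2OC)nn1` gives 15.4%. Compound 3 stands second highest of the three; its nearest neighbour is compound 1, and the step of a number 1.2 percentage points lower from compound 1 to compound 3 (within the scatter), while the step of a number 9.3 percentage points higher from compound 2 to compound 3 (within the scatter). Going by the values given here, only the step of a number 10.5 percentage points lower from compound 1 to compound 2 (beyond the scatter).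

Compound 4 `COc1nc2ccc(Br)cc2cc1C(c1ccccc1)n1cc(CCCO)nn1` differs from compound 3 in one place: 3-hydroxypropyl in place of ethoxycarbonyl on an aromatic carbon. The two steps that bear on this change are those replacing an alkyl chain on the same aromatic carbon with ethoxycarbonyl, from compound 1 and from compound 2 to compound 3; both stayed within the scatter. Among the compounds with values here, no measured compound carries a hydroxypropyl group or any hydrogen-bond donor at that position, so the data give no direct guide for it. Given those two small steps, compound 4 is expected to show no step beyond the scatter, the estimated step being a number 3.4 percentage points lower from compound 3 to compound 4 (within the scatter). Compound 4 is therefore estimated at 12%, between 0% and 28%.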

Compound 4, a percentage reported as inhibition, at one concentration (the size of the read-out at that concentration, not a potency): 25.5%
For compound 4 the middle estimate is 13.5 percentage points below the measured one, and the stated range covers the measured number.
By their numbers in this assay, from the lowest: compounds 2, 3, 1 and 4 (each within the scatter of the next, the first and the last beyond it).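

In this assay the group at this aromatic carbon of the five-membered ring now carries a hydrogen-bond donor, and the change from ethoxycarbonyl to 3-hydroxypropyl gives a number 10.1 percentage points higher from compound 3 to compound 4 (beyond the scatter) so this position does respond to a swap, whereas the earlier changes from an alkyl chain to ethoxycarbonyl stayed within the scatter. Set against the hexyl chain the change also stands out, with a number 19.4 percentage points higher from compound 2 to compound 4 (beyond the scatter) but set against the heptyl chain it does not, with a number 8.9 percentage points higher from compound 1 to compound 4 (within the scatter) so compound 4 cannot be separated from compound 1. Nothing available explains these steps.

Whether the hydroxy group itself accounts for the steps stays open, as a plain propyl chain at this carbon would be needed to tell. Going by these compounds, what a 3-aminopropyl group or a carboxylic acid would give here is equally open.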